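Cytotoxicity of a Trifluoromethylbenzyl Isomer Pair in Keratinocytes

This account rests on a few compounds, and the source may have more. Where it says the series, first, only, none or still open, it means among the compounds named here.

Measured compounds:
- compound 1, `C/C(C#Cc1ccccc1)=N\N/C(N)=N/S(=O)(=O)c1cc(C)c(Cl)cc1SCc1cccc(C)c1`: "not determined" (no result reported) in an ADME assay on HaCaT cells (Homo sapiens) for cytotoxicity, read by MTT assay, with a stated time of 72 h; a lower number here means a stronger inhibitor, a higher number a weaker inhibitor
- compound 2, `C/C(C#Cc1ccccc1)=N\N/C(N)=N/S(=O)(=O)c1cc(C)c(Cl)cc1SCc1ccccc1C(F)(F)F`: 18000 nM

Compound 2 carries the only number shown in this assay; compound 1 was not given a value. Compound 3, `C/C(C#Cc1ccccc1)=N\N/C(N)=N/S(=O)(=O)c1cc(C)c(Cl)cc1SCc1cccc(C(F)(F)F)c1`, differs from compound 2 by 3-(trifluoromethyl)phenyl in place of 2-(trifluoromethyl)phenyl on a saturated chain carbon bound to a sulfur. Going by the values given here, no measured pair shows what such a change does here, so the step from compound 2 to compound 3 is expected to stay within the scatter of this assay, with no direction favoured, as no change at the digits printed from compound 2 to compound 3 (within the scatter). For compound 3 the estimated value is 18000 nM, within a range from 7000 nM to 45000 nM.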

Compound 3, half-maximal inhibitory concentration: 105000 nM
Beside the measured number, compound 3's estimate is 5.8-fold (0.77 log units) below it, outside the stated range (above it).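

In this assay, going by these compounds alone, 3-(trifluoromethyl)phenyl in place of 2-(trifluoromethyl)phenyl on a saturated chain carbon bound to a sulfur gives a 5.8-fold higher number from compound 2 to compound 3 (0.77 log units; beyond the scatter) and provides the first readable step at this position. Compounds 2 and 3 hold the same atoms, joined differently, so the number responds to where the trifluoromethyl group sits on the ring alone, and compound 3 is the weaker inhibitor of the two. Nothing at hand accounts for this difference. Still open, from the compounds shown here alone, is how compound 1 compares with either compound, and whether an amine or a carboxylic acid on that ring would move the number further.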